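Methoxy on the phenyl ring of compound 1

The source may report more compounds than this note shows. Statements on the series, on what has been measured and on what is new or still open speak of the compounds shown alone.

Three members of this series carry a measurement in a functional assay on aorta (strain Wistar) for inhibition, with Thoracic aorta (Rattus norvegicus) as the target; on this read-out higher numbers stand for weaker inhibition and lower numbers for stronger inhibition. Compound 1 `COc1nc(-c2cc3ccccc3o2)cc(-c2ccccc2)c1C#N` gives 232000 nM. Compound 2 `CCOc1nc(-c2cc3ccccc3o2)cc(-c2ccccc2)c1C#N` gives 310000 nM, and compound 3 `CCOc1nc(-c2cc3ccccc3o2)cc(-c2ccc(Br)cc2)c1C#N` gives 227000 nM. All three numbers sit within the scatter of one another, so compound 1 is neither set apart from compound 2 nor from compound 3; the step of a 1.3-fold higher number from compound 1 to compound 2 (0.13 log units; within the scatter) and the step of a 1.4-fold lower number from compound 2 to compound 3 (0.14 log units; within the scatter) both stay inside what repeated measurements would show.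

Compound 4 `COc1ccc(-c2cc(-c3cc4ccccc4o3)nc(OC)c2C#N)cc1` is not yet measured. It differs from compound 1 by methoxy in place of hydrogen on an aromatic carbon. The nearest measured comparison is the step of a 1.4-fold lower number from compound 2 to compound 3 (0.14 log units; within the scatter), which also places a single substituent on an aromatic carbon of the same ring and leaves the number where it was. The step of a 1.3-fold higher number from compound 1 to compound 2 (0.13 log units; within the scatter), a change on the other side of the core, was likewise flat. Going by the values given here, neither bears closely on a methoxy group, and no measured compound carries one on that ring, so the expectation rests on the general flatness of the series.

The expected step of no change at the digits printed from compound 1 to compound 4 (within the scatter) is therefore none beyond the scatter. For compound 4 in this assay the estimate is 232000 nM, with a range from 110000 nM to 490000 nM.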

Compound 4, half-maximal inhibitory concentration: 262000 nM
The estimate for compound 4 lay 1.1-fold (0.05 log units) below the measured number, and the stated range covers the measured number.
By their numbers in this assay, from the lowest: compounds 3, 1, 4 and 2 (each within the scatter of the next).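

Phenyl to 4-methoxyphenyl puts an oxygen-linked group on the ring that had so far been probed only with bromo, here para to a large group, and in this assay it gives a 1.1-fold higher number from compound 1 to compound 4 (0.05 log units; within the scatter). Read beside a 1.4-fold lower number from compound 2 to compound 3 (0.14 log units; within the scatter), this shows two different substituents on this ring, each on its own parent, with neither step leaving the scatter, so the flatness seen with bromo also holds for methoxy on the compound with the shorter alkoxy group on the core. Nothing available explains this insensitivity, and it remains a description of the numbers only.

Going by these compounds, whether the ring stays as flat with an amine or a carboxylic acid in that place remains open, as does the outcome of moving the methoxy to another carbon of the ring. Also open, on these data alone, is whether a longer chain in place of the methoxy or ethoxy on the core, or a different group in place of the nitrile, would shift the number beyond the scatter.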